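Replacing a methoxy with a methyl on a side chain

This account rests on a few compounds, and the source may have more. Where it says the series, first, only, none or still open, it means among the compounds named here.

Compound 2, with the structure `COCC[C@@H]1C[C@@H](c2ccc(Cl)c(Cl)c2)[C@H](NC(=O)c2cc(-c3c(Cl)cnn3C)c(Cl)o2)CN1`, was tested in an assay for inhibition of RAC-alpha serine/threonine-protein kinase (Homo sapiens), read by HTRF, with a stated time of 1 h (on this read-out higher numbers stand for weaker inhibition and lower numbers for stronger inhibition), and gave 7.01 nM. Among the two compounds measured so far, compound 2 stands at the higher number: compound 1, with the structure `CNC(=O)C[C@@H]1C[C@@H](c2ccc(F)c(F)c2)[C@H](NC(=O)c2cc(-c3c(Cl)cnn3C)c(Cl)o2)CN1`, gives 1.37 nM in this assay, a lower number that lies beyond the usual scatter of such measurements, so compound 1 is the stronger inhibitor of the pair. Compound 1 and compound 2 differ in more than one place, so their values alone are shown here.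

Compound 3, with the structure `CCC[C@@H]1C[C@@H](c2ccc(Cl)c(Cl)c2)[C@H](NC(=O)c2cc(-c3c(Cl)cnn3C)c(Cl)o2)CN1`, has not yet been measured in this assay. It differs from compound 2 in a single spot: methyl in place of methoxy on a saturated chain carbon, two bonds along the chain from a saturated ring carbon. The rest of the molecule is unchanged. Going by the values given here, no measured pair with the same change is available for guidance, so the step is expected to be modest, a 1.4-fold higher number from compound 2 to compound 3 (0.15 log units; within the scatter), in the direction of a slightly higher number that may not exceed the scatter. Compound 3 is therefore estimated at 10 nM, with a range from 3.5 nM to 30 nM.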

Compound 3, half-maximal inhibitory concentration: 10.4 nM
For compound 3 the middle estimate is 1.0-fold (0.02 log units) below the measured one; low and high end bracket the measured number.
By their numbers in this assay, from the lowest: compound 1; then compounds 2 and 3 (each within the scatter of the next).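

At this position, on a saturated chain carbon, two bonds along the chain from a saturated ring carbon, the change from 2-methoxyethyl to propyl in this assay gives a 1.5-fold higher number from compound 2 to compound 3 (0.17 log units; within the scatter) and so leaves the two compounds indistinguishable on this read-out. The methoxy carries a hydrogen-bond acceptor and the methyl carries none, yet compound 3 reads in the same range as compound 2, so in this pair the oxygen of the chain is not needed for inhibition at this level. Nothing measured here explains why the two compounds read alike.

This single pair says nothing about how much the position tolerates more generally: an amine or a carboxylic acid at the end of the chain, a longer chain such as butyl, or a shorter one such as ethyl could each read quite differently from compound 2 and compound 3. Compound 1 differs from both in more than one place, so it cannot show whether the same swap would also leave the number within the scatter on the core of compound 1.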